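The source may report more compounds than this note shows. Statements on the series, on what has been measured and on what is new or still open speak of the compounds shown alone.

Going by the values given here, in an ADME assay on U2OS cells (Homo sapiens) for cytotoxicity (on this read-out higher numbers stand for lower toxicity in this test and lower numbers for higher toxicity in this test), compound 3 (`CC(C)(C)c1ccc(-c2nccc3[nH]c(C(C)(C)O)cc23)cc1`) gives 35300 nM as the higher of the two numbers so far. Compound 2 (`CCSc1ccc(-c2nccc3[nH]c(C(C)(C)O)cc23)cc1`) gives 17200 nM and compound 1 (`CC(C)(O)c1cc2c(-c3ccc(C#N)cc3)nccc2[nH]1`) stands as "not determined" (no result reported) with no number reported. The next entry, compound 4 (`CC(C)(O)c1cc2c(-c3ccc(F)cc3)nccc2[nH]1`), carries fluoro in place of tert-butyl on an aromatic carbon and has not yet been measured. Among the compounds with values here, the one measured step at this aromatic carbon exchanges ethylsulfanyl for tert-butyl and is modest (a 2.1-fold higher number from compound 2 to compound 3 (0.31 log units; beyond the scatter)), only just beyond the scatter. Within the data shown here, no measured compound carries fluoro, so that step suggests a likely size of change but gives no direction. In this assay a step of no more than similar size is therefore expected, most likely none beyond the scatter. The expected change is small (a 1.3-fold lower number from compound 3 to compound 4 (0.10 log units; within the scatter)) and is estimated with no firm direction. For compound 4 the estimated value is 28000 nM (expected range 13000 nM to 55000 nM).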

Compound 4, half-maximal cytotoxic concentration: 93600 nM
For compound 4 the middle estimate is 3.3-fold (0.52 log units) below the measured one; measured number outside the range, above it.
By their numbers in this assay, from the lowest: compound 2; then compound 3; then compound 4.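

In this assay, going by these compounds alone, this aromatic carbon now has a first reading for fluoro: replacing tert-butyl gives a 2.7-fold higher number from compound 3 to compound 4 (0.42 log units; beyond the scatter), which settles the direction for this pair. Replacing ethylsulfanyl with fluoro gives a 5.4-fold higher number from compound 2 to compound 4 (0.74 log units; beyond the scatter), so compound 4 has the highest of the three numbers, the lowest toxicity in this test, and both of its steps lie beyond the scatter. No supporting data bear on why the number rises with fluoro at this position.

On these data alone, three numbers at one aromatic carbon cannot establish a trend with the size of the group, so that relation remains open. As far as these compounds go, how an amine, a carboxylic acid or a longer chain at this carbon would compare also remains open, as does whether the fluoro result would hold with other changes to the shared core.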